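This account rests on a few compounds, and the source may have more. Where it says the series, first, only, none or still open, it means among the compounds named here.

Among the compounds with values here, compound 1, `O=C(CSc1nc2cccnc2[nH]1)Nc1cccc(Br)c1`, is one of two compounds measured in an assay on isolated protein for inhibition of Ectonucleotide pyrophosphatase/phosphodiesterase family member 1 (Homo sapiens), tested at 10 uM; on this read-out higher numbers stand for more inhibition at the one concentration tested (going by the name of the read-out) and lower numbers for less inhibition. In this assay compound 1 gives 23%. The other measured compound, compound 2, `O=C(CSc1nc2cccnc2[nH]1)Nc1ccc(F)cc1`, gives 30% in this assay. These two numbers lie within the usual scatter of each other, so compound 1 cannot be said to inhibit more or less than compound 2; they stand together at the same modest level.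

Compound 3, `COc1cccc(NC(=O)CSc2nc3cccnc3[nH]2)c1`, is not yet measured. It differs from compound 1 in one place: methoxy in place of bromo on an aromatic carbon.

Within the data shown here, only one measured step speaks to changes on that phenyl ring, and it is a number 7 percentage points higher from compound 1 to compound 2 (within the scatter), a step within the scatter. Among the measured compounds shown here, it exchanged a halogen for another halogen at a different place, so it bears on the methoxy-for-bromo change only loosely, and no measured step shows a change of this kind moving the number beyond the scatter. The expected step of a number 2 percentage points higher from compound 1 to compound 3 (within the scatter) is therefore estimated to stay within the scatter. Compound 3 is expected to give 25%, with a range from 5% to 45%.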

Compound 3, a percentage reported as inhibition, at one concentration (the size of the read-out at that concentration, not a potency): 30%
Beside the measured number, compound 3's estimate is 5 percentage points below it, within the range that was stated.
By their numbers in this assay, from the lowest: compounds 1, 2 and 3 (each within the scatter of the next).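

The exchange of bromo for methoxy gives a number 7 percentage points higher from compound 1 to compound 3 (within the scatter) in this assay. Unlike the earlier step, which altered both the halogen and its place on the phenyl ring, this one keeps the place fixed and changes only the group, meta to a large group. The entering methoxy carries a hydrogen-bond acceptor and the leaving bromo carries none, yet the number does not move beyond the scatter, so at this place the two groups cannot be told apart; no measurement here offers an explanation for that.

What stays open is whether any group at this place can move the number beyond the scatter, since only bromo and methoxy are shown there, and an amine, a carboxylic acid or a longer chain such as butoxy could behave differently. The compounds shown also leave open whether changes elsewhere in the molecule, such as on the shared core or the chain joining it to the amide, matter more than changes on this phenyl ring.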